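Series notes: the step from compound 2 to compound 4

The source may report more compounds than this note shows. Statements on the series, on what has been measured and on what is new or still open speak of the compounds shown alone.

Three compounds share one core and differ only in the five-membered ring attached to the chain. In a functional assay on CHO cells for antagonist activity at prostaglandin E2 receptor EP3 subtype (Homo sapiens), read by cAMP accumulation, with a stated time of 30 min (a lower number here means a stronger inhibitor, a higher number a weaker inhibitor), compound 1 `CC(C)[C@@H](C[C@H]1SC(=O)NC1=O)c1ccc(-c2ccc3cccc(F)c3c2)[nH]c1=O` gives 17 nM, compound 2 `CC(C)C(c1ccc(-c2ccc3cccc(F)c3c2)[nH]c1=O)C1C(=O)NC(=O)N1C` gives 320 nM, and compound 3 `CC(C)[C@@H](c1ccc(-c2ccc3cccc(F)c3c2)[nH]c1=O)[C@@H]1OC(=O)NC1=O` gives 610 nM. Compound 2 stands second highest of the three numbers; its value and that of compound 3 lie within the scatter of each other, whereas compound 1 sits well below both, beyond the scatter. Compound 4 `CC(C)C(/C=C1/C(=O)NC(=O)N1C)c1ccc(-c2ccc3cccc(F)c3c2)[nH]c1=O` is not yet measured. It differs from compound 2 thus: a group of 9 heavy atoms (5 carbon, 2 nitrogen, 2 oxygen; one five-membered non-aromatic ring with 2 hetero atoms) in place of a group of 8 heavy atoms (4 carbon, 2 nitrogen, 2 oxygen; one five-membered non-aromatic ring with 2 hetero atoms), on a saturated chain carbon bound to an aromatic carbon and a saturated chain carbon. Among the measured compounds shown here, no step between measured compounds matches this change, so no direction can be read from the series. The estimate for compound 4 in this assay is 400 nM, with a range from 120 nM to 1500 nM. The expected step of a 1.3-fold higher number from compound 2 to compound 4 (0.10 log units; within the scatter) is none beyond the scatter.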

Compound 4, half-maximal inhibitory concentration: 11 nM
Beside the measured number, compound 4's estimate is 36-fold (1.56 log units) above it, and the stated range ends above it.
By their numbers in this assay, from the lowest: compounds 4 and 1 (each within the scatter of the next); then compounds 2 and 3 (each within the scatter of the next).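

In this assay, this place on the saturated chain carbon proves sensitive to how the five-membered ring is carried: the group of 9 heavy atoms, with 3 double bonds outside aromatic rings, replacing 3-methyl-2,5-dioxoimidazolidin-4-yl gives a 29-fold lower number from compound 2 to compound 4 (1.46 log units; beyond the scatter). Hydrogen-bond donor and acceptor counts stay the same across this step. No measurement shown accounts for its size.

Still open, going by these compounds, is whether the added carbon or the added double bond carries the step. Also open, on these data alone, is how a carboxylic acid at this place would compare.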